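Chain shortening in the aryl ether series of compound 3

The compounds below may be only part of what the source reports. "The series", "measured", "known", "first", "only" and "open" are said of these compounds alone.

Going by the values given here, compound 3 `Clc1ccnc2cc(OCCCc3ccccc3)ccc12` holds the lowest number of the three measured members: in a functional assay on HCT-116 cells (Homo sapiens) for cytotoxicity, read by MTT assay, with a stated time of 48 h (a lower number here means a stronger inhibitor, a higher number a weaker inhibitor), compound 3 gives 800 nM. Compound 1 `CCCCCCOc1ccc2c(Cl)ccnc2c1` gives 2440 nM in this assay, and compound 2 `CCOc1ccc2c(Cl)ccnc2c1` gives 3160 nM. The step of a 3.1-fold lower number from compound 1 to compound 3 (0.48 log units; beyond the scatter) and the step of a 4.0-fold lower number from compound 2 to compound 3 (0.60 log units; beyond the scatter) both run beyond the scatter, whereas the step of a 1.3-fold higher number from compound 1 to compound 2 (0.11 log units; within the scatter) stays within it.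

Compound 4 `Clc1ccnc2cc(OCCc3ccccc3)ccc12` is not yet measured. Relative to compound 3 the change is phenyl in place of benzyl on a saturated chain carbon, two bonds along the chain from an oxygen on an aromatic ring, so the aromatic ring on the ether chain is retained and only the chain between the ring oxygen and that aromatic ring differs. Among the compounds with values here, the closest precedent is the step from compound 1 to compound 2, where a change in chain length alone left the number within the scatter. The two steps that moved the number beyond the scatter, from compound 1 to compound 3 and from compound 2 to compound 3, each introduced the aromatic ring itself, which compound 4 keeps. On this basis the step of a 1.2-fold higher number from compound 3 to compound 4 (0.07 log units; within the scatter) is expected to be small, with no direction claimed beyond the scatter. Compound 4 is therefore estimated at 950 nM in this assay, within a range of 400 nM to 2200 nM.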

Compound 4, half-maximal inhibitory concentration: 2180 nM
Compound 4: the middle estimate sits 2.3-fold (0.36 log units) below what was measured; measured number inside the range.
By their numbers in this assay, from the lowest: compound 3; then compounds 4, 1 and 2 (each within the scatter of the next).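

At this place, on a saturated chain carbon, two bonds along the chain from an oxygen on an aromatic ring, phenyl in place of benzyl gives a 2.7-fold higher number from compound 3 to compound 4 (0.44 log units; beyond the scatter) in this assay, so with the aromatic ring retained, the length of the chain carrying it does change the number, which the step without that ring did not show. The ring alone does not account for the lower number of compound 3: a 1.4-fold lower number from compound 2 to compound 4 (0.16 log units; within the scatter) and a 1.1-fold lower number from compound 1 to compound 4 (0.05 log units; within the scatter) both stay within the scatter, so compound 4 keeps the ring yet cannot be told apart from the two compounds lacking it. Among these four compounds, compound 3 alone stands apart, with steps beyond the scatter to each of the others, which points to benzyl at this place, rather than the ring or the chain alone, as what goes with the lower number in this small set.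

Nothing at hand explains why this one chain length differs. Still open, as far as these compounds go, is whether a longer chain ending in phenyl keeps, improves or loses the number of compound 3, and how an amine or a carboxylic acid at the end of the chain would compare.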